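Changing the Carboxy Group on Compound 3

The source may hold more compounds than are shown below. What is called first, only, known or untested is meant among the compounds shown, and "the series" means these compounds.

Measured in a functional assay on MCF7 cells (Homo sapiens), read by MTT assay, with a stated time of 48 h; a lower number here means a stronger inhibitor, a higher number a weaker inhibitor:
- compound 1 `CCN(CC)CCNC(=O)c1ccc(C(CC)(CC)c2ccc(OCC(=O)C(C)(C)C)c(C)c2)n1CC`: 690 nM
- compound 2 `CCn1c(C(=O)NCCN)ccc1C(CC)(CC)c1ccc(OCC(=O)C(C)(C)C)c(C)c1`: 75 nM
- compound 3 `CC[C@@H](C)[C@H](NC(=O)c1ccc(C(CC)(CC)c2ccc(OCC(=O)C(C)(C)C)c(C)c2)n1CC)C(=O)O`: 160 nM

Compound 3 holds the middle of the three values. Compound 4 `CCn1c(C(=O)N(C)CC(=O)O)ccc1C(CC)(CC)c1ccc(OCC(=O)C(C)(C)C)c(C)c1` has not been measured yet. It differs from compound 3 as follows: (carboxymethyl)(methyl)amino in place of (1-carboxy-2-methylbutyl)amino on a carbonyl carbon. Two modest measured steps bear on this change, since both put the 1-carboxy-2-methylbutyl group on an amide-type nitrogen: a 4.3-fold lower number from compound 1 to compound 3 (0.63 log units; beyond the scatter) and a 2.1-fold higher number from compound 2 to compound 3 (0.33 log units; beyond the scatter). Within the data shown here, neither compares two carboxy-bearing groups, so no direct precedent exists. A small step is therefore expected in this assay, with nothing clearly beyond the scatter: a 1.6-fold higher number from compound 3 to compound 4 (0.19 log units; within the scatter). For compound 4 the estimated value is 250 nM, within an expected range of 70 nM to 800 nM.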

Compound 4, half-maximal inhibitory concentration: 28600 nM
The estimate for compound 4 lay 110-fold (2.06 log units) below the measured number, outside the stated range (above it).
By their numbers in this assay, from the lowest: compound 2; then compound 3; then compound 1; then compound 4.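

Two groups that both carry a carboxy group can give very different numbers on this carbonyl carbon: (carboxymethyl)(methyl)amino in place of (1-carboxy-2-methylbutyl)amino gives a 180-fold higher number from compound 3 to compound 4 (2.25 log units; beyond the scatter) in this assay. Set against the two amine-bearing groups, the same group gives a 380-fold higher number from compound 2 to compound 4 (2.58 log units; beyond the scatter) and a 41-fold higher number from compound 1 to compound 4 (1.62 log units; beyond the scatter), and all three steps exceed any seen among the earlier compounds. Nothing available accounts for this large rise.

This change both replaces the amide hydrogen with a methyl and shortens the chain, and the compounds shown cannot separate these two differences. As far as these compounds go, the (carboxymethyl)amino group, which keeps the amide hydrogen and the short chain, remains open.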